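The source may report more compounds than this note shows. Statements on the series, on what has been measured and on what is new or still open speak of the compounds shown alone.

Compound 1 `COc1ccc2c(c1)C(n1ccccc1=O)=CC(C)(C)O2`, compound 2 `CC(=O)c1ccc2c(c1)C(n1ccccc1=O)=CC(C)(C)O2` and compound 3 `CC1(C)C=C(n2ccccc2=O)c2cc(C=O)ccc2O1` have been measured. In a functional assay (aorta) with Rattus norvegicus as the target (a lower number here means a less potent compound, a higher number a more potent compound, by a factor of ten per unit of this negative logarithm), compound 1 gives 6.55, compound 2 gives 7.37, and compound 3 gives 6.91.

Compound 3 stands second of the three measured numbers: a number 0.36 log units higher from compound 1 to compound 3 (beyond the scatter), while a number 0.46 log units lower from compound 2 to compound 3 (beyond the scatter). Compound 4 `CC1(C)C=C(n2ccccc2=O)c2cc(Br)ccc2O1` differs from compound 3 in one place: bromo in place of formyl on an aromatic carbon. Within the data shown here, no measured step exchanges a group of this kind, so none bears directly on it; the nearest are a number 0.82 log units higher from compound 1 to compound 2 (beyond the scatter) and a number 0.46 log units lower from compound 2 to compound 3 (beyond the scatter), which show that exchanges at this aromatic carbon move this assay by modest amounts in either direction. A step of comparable size is possible here, with no clear direction to favour. Compound 4 is therefore expected to give about 6.8, within 6.2 to 7.4. That estimate means a number 0.11 log units lower from compound 3 to compound 4 (within the scatter), expected to stay within the scatter.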

Compound 4, logarithm of the reciprocal of the active concentration, log(1/C): 7.84
Beside the measured number, compound 4's estimate is 1.04 log units below it; the whole stated range lies below it.
By their numbers in this assay, from the lowest: compound 1; then compound 3; then compound 2; then compound 4.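

With bromo on this aromatic carbon, this assay reads a number 0.93 log units higher from compound 3 to compound 4 (beyond the scatter) and a number 0.47 log units higher from compound 2 to compound 4 (beyond the scatter) and a number 1.29 log units higher from compound 1 to compound 4 (beyond the scatter) in turn. Compound 4 thus holds the highest number of the four, and bromo, counted with no hydrogen-bond acceptor, shows that the acceptor of formyl is not required at this carbon for a high number. Nothing shown accounts for this rise. The compounds leave open how a chloro group, an iodo group, a nitrile or an amine would compare at this carbon. They also leave open whether bromo would keep its lead on a different core.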